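Methyl in place of biaryl on the sulfonyl arene

The compounds below may be only part of what the source reports. "The series", "measured", "known", "first", "only" and "open" are said of these compounds alone.

Three members of the series have numbers in a functional assay on DLD-1 cells (Homo sapiens) for antiproliferative activity, read by CellTiter-Glo, with a stated time of 72 h (a lower number here means a stronger inhibitor, a higher number a weaker inhibitor), so far. Compound 1 `Cc1cc(C)c(S(=O)(=O)N2CCC(C3OCC(C)CO3)CC2)c(C)c1` sits at the assay limit: in this assay compound 1 gives > 5000 nM, which is a limit and not a number (the limit of > 5000 nM in this assay, at which 1 of the 3 values shown sits). Compound 2 `CC1CCN(C2CCN(S(=O)(=O)c3cccc(-c4ccccc4F)c3)CC2)CC1` gives 10 nM in this assay, the lowest of the two numbers shown. Compound 3 `CC1CCN(C2CCN(S(=O)(=O)c3ccc(OCc4ccccc4)cc3)CC2)CC1` gives 385 nM in this assay, and the gap between compound 2 and compound 3 lies beyond the scatter.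

Compound 4 `Cc1cccc(S(=O)(=O)N2CCC(N3CCC(C)CC3)CC2)c1` has not yet been measured. It differs from compound 2 in one place: methyl in place of 2-fluorophenyl on an aromatic carbon. Compound 2 and compound 3 show that the sulfonyl arene bears the group that separates the two numbers, and in compound 4 that arene carries only a methyl where the larger group sat. The step from compound 2 to compound 4 is therefore expected to be large and toward a weaker inhibitor, a 150-fold higher number from compound 2 to compound 4 (2.18 log units; beyond the scatter), rather than within the scatter. For compound 4 the estimate in this assay is 1500 nM, with a range from 300 nM to 8000 nM; a result at the assay limit cannot be excluded.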

Compound 4, half-maximal inhibitory concentration: 25 nM
Beside the measured number, compound 4's estimate is 60-fold (1.78 log units) above it; measured number below the stated range.
By their numbers in this assay, from the lowest: compound 2; then compound 4; then compound 3. At a limit, above all of these: compound 1.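

Going by these compounds alone, this position on the sulfonyl arene gives the first readable single-place step: in this assay, methyl in place of 2-fluorophenyl gives a 2.5-fold higher number from compound 2 to compound 4 (0.40 log units; beyond the scatter), a step that is modest though beyond the scatter. The aromatic ring of the 2-fluorophenyl group and most of the group's heavy atoms, 7 falling to 1, can therefore leave this carbon, meta to a large group, with the number staying low, so a biaryl is not required here for a strong inhibitor, although compound 2 keeps the lower number of this pair. No measured property among the compounds shown bears on this step, and nothing shown accounts for its size.

On these data alone, with only methyl and 2-fluorophenyl at this carbon, it remains open whether a plain hydrogen, a methoxy group, an amine or a carboxylic acid there would give a number near that of compound 4 or compound 2. As far as these compounds go, it is also open whether the same change behaves alike at another carbon of the arene, or on a different group at the far end of the shared core.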